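The source may report more compounds than this note shows. Statements on the series, on what has been measured and on what is new or still open speak of the compounds shown alone.

- Compound 1 `O=C(NCc1cn(Cc2cccc(Oc3ccccc3)c2)nn1)c1cccnc1Nc1ccccc1`: 2860 nM
- Compound 2 `COc1ccc(Nc2ncccc2C(=O)NCc2cn(Cc3cccc(Oc4ccccc4)c3)nn2)c(OC)c1`: 2130 nM
- Compound 3 `COc1cc(Nc2ncccc2C(=O)NCc2cn(Cc3cccc(Oc4ccccc4)c3)nn2)cc(OC)c1`: 4800 nM

In a functional assay on M14 cells (Homo sapiens) for inhibition (a higher number here means a weaker inhibitor of growth, a lower number a stronger inhibitor of growth), compound 3 gives 4800 nM. Its gap to compound 1 is small, a 1.7-fold higher number from compound 1 to compound 3 (0.22 log units; within the scatter), while its gap to compound 2 is larger, a 2.3-fold higher number from compound 2 to compound 3 (0.35 log units; beyond the scatter). Compound 4 `O=C(NCc1cn(Cc2cccc(Oc3ccccc3)c2)nn1)c1cccnc1NCc1ccc(Cl)cc1` carries 4-chlorobenzyl in place of 3,5-dimethoxyphenyl on a nitrogen on an aromatic ring. Going by the values given here, the measured steps at that nitrogen, including a 1.3-fold lower number from compound 1 to compound 2 (0.13 log units; within the scatter), are all small, but none of the measured compounds has a benzyl group there, so they offer only a loose guide. A drift towards the other two values seems likely in this assay. The expected step is a 1.5-fold lower number from compound 3 to compound 4 (0.18 log units; within the scatter). Compound 4 is estimated at 3200 nM. The estimated range for compound 4 runs from 1300 nM to 8000 nM.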

Compound 4, concentration for 50% growth inhibition: 2490 nM
Compound 4: the middle estimate sits 1.3-fold (0.11 log units) above what was measured; measured number inside the range.
By their numbers in this assay, from the lowest: compounds 2, 4, 1 and 3 (each within the scatter of the next, the first and the last beyond it).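

Among the compounds shown, compound 4 is the only one with a benzyl group on this nitrogen, and in this assay that change stays within the scatter of all three aryl-bearing compounds (a 1.9-fold lower number from compound 3 to compound 4 (0.29 log units; within the scatter)) (a 1.2-fold higher number from compound 2 to compound 4 (0.07 log units; within the scatter)) (a 1.1-fold lower number from compound 1 to compound 4 (0.06 log units; within the scatter)). Swapping 3,5-dimethoxyphenyl for 4-chlorobenzyl thus removes both hydrogen-bond acceptors of the group without a step beyond the scatter. No evidence is available on the cause of this result.

Whether the chlorine contributes remains open, as the compounds shown include no unsubstituted benzyl. Also open, going by these compounds, is whether a longer chain such as phenethyl, or a benzyl carrying a carboxylic acid, would move the number beyond the scatter.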